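The source may report more compounds than this note shows. Statements on the series, on what has been measured and on what is new or still open speak of the compounds shown alone.

Working notes on a small amide series in an ADME assay on HEK293 cells (Homo sapiens) for cytotoxicity, read by reporter gene assay and resazurin assay, with a stated time of 48 h; on this read-out higher numbers stand for lower toxicity in this test and lower numbers for higher toxicity in this test.

Compound 1 `COc1c(Br)cccc1C(=O)Nc1ccccc1` is measured only as a limit of the assay: in this assay compound 1 gives > 100000 nM. Compound 2 `COc1ccccc1C(=O)Nc1ccccc1` likewise sits at a limit: in this assay compound 2 gives > 100000 nM. The change between them is hydrogen in place of bromo on an aromatic carbon, and the step it makes, a step that the two limits leave unreadable from compound 1 to compound 2, cannot be sized, which follows from the limit of > 100000 nM in this assay, at which 2 of the 3 values shown sit.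

Compound 3 `O=C(Nc1ccc(Sc2nc3ccccc3s2)c(Cl)c1)c1cc(Br)ccc1O` carries a different core; how the core of compound 3 differs from the core of compound 1 is not broken down here. In this assay, going by the values given here, compound 3 gives 45000 nM, the one value in the set that is a number rather than a limit.

Compound 4 `O=C(Nc1ccc(Sc2nc3ccccc3s2)c(Cl)c1)c1ccccc1O` has not been measured in this assay. It differs from compound 3 by hydrogen in place of bromo on an aromatic carbon. Among the compounds with values here, this is the same kind of change as the one from compound 1 to compound 2, though the surroundings differ: in compound 1 the bromo that leaves stands ortho to a methoxy group (2 heavy atoms) and meta to a group of 9 heavy atoms, whereas in compound 3 it stands meta to a large group and para to a hydroxy group (1 heavy atom).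

For compound 4 a step of a 1.6-fold higher number from compound 3 to compound 4 (0.19 log units; within the scatter) is expected, set beside the earlier unreadable step, and it rests on compound 3 giving 45000 nM with a change that cannot be read in the measured pair. The estimate for compound 4 in this assay is 70000 nM, between 30000 nM and 160000 nM.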

Compound 4, half-maximal cytotoxic concentration: 64000 nM
Compound 4: middle estimate off by 1.1-fold (0.04 log units), on the high side; the range from low to high includes it.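

On the core of compound 3, the exchange of 5-bromo-2-hydroxyphenyl for 2-hydroxyphenyl in this assay gives a 1.4-fold higher number from compound 3 to compound 4 (0.15 log units; within the scatter), so on this core the values with and without the bromo cannot be told apart. The same exchange on the core of compound 1 gives no size to set beside it, because compound 1 and compound 2 both stand at a limit of the assay rather than at a number: the limit of > 100000 nM in this assay, at which 2 of the 4 values shown sit. The series therefore shows one readable pair on one core and does not show that the exchange behaves alike on both cores, so the result on the core of compound 3 cannot be taken as a transfer of the step from one core to the other.

From the compounds shown here alone, what an amine or a carboxylic acid would give at the place the bromo occupies stays open, as does whether any group there would move the value on the core of compound 3 beyond the scatter. Also open, going by these compounds, is whether a hydrogen-for-bromo exchange can be sized at all on the core of compound 1, where neither value shown is a number.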